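The compounds below may be only part of what the source reports. "The series", "measured", "known", "first", "only" and "open" are said of these compounds alone.

The measured compounds and their values in an ADME assay on Vero cells (Chlorocebus sabaeus) for cytotoxicity, read by luminescence, with a stated time of 2 days; on this read-out higher numbers stand for lower toxicity in this test and lower numbers for higher toxicity in this test:
compound 1, `CCc1nc2ccc(C)cc2n1CCCCNc1ccc(C)cc1`, 20 uM;
compound 2, `CCc1nc2ccc(C)cc2n1CCCCNc1ccc(C)cc1C`, 20 uM;
compound 3, `CCc1nc2ccc(C)cc2n1CCCOc1ccc(C)cc1`, 15 uM.

Compound 1 and compound 2 differ in one place: methyl in place of hydrogen on an aromatic carbon. That step made no change at the digits printed from compound 1 to compound 2 (within the scatter). The difference between the core of compound 1 and the core of compound 3 is not broken down here. Compound 4, `CCc1nc2ccc(C)cc2n1CCCOc1ccc(C)c(C)c1`, is not yet measured; it differs from compound 3 by methyl in place of hydrogen on an aromatic carbon. Among the compounds with values here, this is the same kind of change as the one from compound 1 to compound 2, but the surroundings differ: in compound 2 the entering methyl sits ortho to a large group and meta to a methyl group, whereas in compound 4 it sits ortho to a methyl group and meta to a large group. Because the earlier step gave no change at the digits printed from compound 1 to compound 2 (within the scatter), a similarly small step is expected here, no change at the digits printed from compound 3 to compound 4 (within the scatter). Compound 4 is therefore estimated at 15 uM in this assay, most likely between 7 uM and 30 uM.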

Compound 4, half-maximal toxic concentration: 7.3 uM
Estimate against measurement, compound 4: 2.1-fold (0.31 log units) above; the range from low to high includes it.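

In this assay, methyl in place of hydrogen on an aromatic carbon gave a 2.1-fold lower number from compound 3 to compound 4 (0.31 log units; beyond the scatter). Set beside the earlier step, the two cores cannot be told apart for this change: the same change on two cores in this assay, no change at the digits printed (within the scatter) from compound 1 to compound 2 and a 2.1-fold lower number (0.31 log units; beyond the scatter) from compound 3 to compound 4, 2.1-fold (0.31 log units) apart, within the scatter of two such steps. This fits a change that carries from one core to the other, but two steps, with the methyl entering at different places on the ring, cannot show that it will behave the same way on every core in the series.

The compounds shown leave open how an amine or a carboxylic acid on the same aromatic ring would read in this assay. They also leave open what the 3,4-dimethylphenyl group would give on the core of compound 1.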